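Swapping a lactam for an aminopyridine on a shared core

A few compounds are considered here, and "the series" means these few. Any claim that something is new, unique, unknown or untested is made for them only; others in the source may bear on it.

Measured so far in a physicochemical assay for lipophilicity, using the shake flask method, in phosphate buffer, measured as octanol-water partition, with a stated time of 30 min, at pH 7.4; a higher number here means a more lipophilic compound, a lower number a more polar compound:
Compound 1 `Cc1ncccc1-c1cnc(NCc2c(F)ccc3c2CCO3)c2nn(CC#N)c(=O)n12` gives 2.2.
Compound 2 `C[C@@H]1CC(=O)N(c2cnc(NCc3c(F)ccc4c3CCO4)n3cnnc23)C1` gives 1.8.
Compound 3 `CN(C)Cc1ccc2c(c1)CN(c1cnc(NCc3c(F)ccc4c3CCO4)n3cnnc13)C2=O` gives 1.6.

Among these three numbers compound 2 sits with compound 3 inside the scatter of a single measurement, so the two cannot be told apart in this assay. Compound 1 stands higher, and its gap to compound 2 lies beyond the scatter. All three share the same core and the same fluorinated side chain, and differ only in the group attached to the core.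

Compound 4 `CN(c1cccnc1)c1cnc(NCc2c(F)ccc3c2CCO3)n2cnnc12` has not yet been measured. It differs from compound 2 in one place: methyl(pyridin-3-yl)amino in place of 4-methyl-2-oxopyrrolidin-1-yl on an aromatic carbon. Among the measured compounds shown here, no pair of measured compounds shows this particular exchange, so no measured step can be borrowed for it.

Starting from compound 2 at 1.8, the step of a number 0.60 log units higher from compound 2 to compound 4 (beyond the scatter) is expected to be a moderate rise, clearly beyond the scatter. Compound 4 is therefore estimated at 2.4, within a range from 1.9 to 3.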

Compound 4, distribution coefficient: 2.6
Compound 4: middle estimate off by 0.20 log units, on the low side, and the stated range covers the measured number.
By their numbers in this assay, from the lowest: compounds 3 and 2 (each within the scatter of the next); then compound 1; then compound 4.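

At this position on the shared core, the attached group can shift the number in this assay well beyond the scatter: methyl(pyridin-3-yl)amino in place of 4-methyl-2-oxopyrrolidin-1-yl gives a number 0.80 log units higher from compound 2 to compound 4 (beyond the scatter). Among the compounds shown here, this is the first measured step at this place, as no earlier pair differed in one place only. The exchange removes a five-membered non-aromatic ring, with its double bond outside the ring and its defined stereocentre, and brings in a six-membered aromatic ring, but no measured evidence says which of these changes accounts for the step.

One exchange alters all these features together, so the separate contributions of the pyridine ring, its ring nitrogen and the methyl on the linking nitrogen stay unresolved. Also open, going by these compounds, is how the number would respond here to a morpholine, a simple phenyl ring or a carboxylic acid.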